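Compound 3 has no number, compound 4 awaits one

A few compounds are considered here, and "the series" means these few. Any claim that something is new, unique, unknown or untested is made for them only; others in the source may bear on it.

Within the data shown here, in an ADME assay on J774.A1 cells (Mus musculus) for cytotoxicity, read by MTT assay, with a stated time of 72 h (on this read-out lower numbers stand for higher toxicity in this test and higher numbers for lower toxicity in this test), compound 1 (`Clc1cccc(COC(CCn2ccnc2)c2cccs2)c1`) gives 46000 nM and compound 2 (`Clc1cccc(COC(CCn2cncn2)c2ccco2)c1`) gives 18600 nM as the only numbers available. For compound 3 (`Clc1ccc(Cl)c(COC(CCn2cncn2)c2cccs2)c1`) the result stands as "not determined" (no result reported), and it has no place on this scale. Compound 4 (`Clc1cccc(COC(CCn2cncn2)c2cccs2)c1`) has yet to be measured. The change hydrogen in place of chloro on an aromatic carbon puts hydrogen in place of chloro on an aromatic carbon, para to a chloro group. Among the measured compounds shown here, with no measured step to go on, no shift beyond the usual scatter is expected in this assay for this change. The expectation therefore leans on compound 1 at 46000 nM and compound 2 at 18600 nM alone. Compound 4 is estimated at 30000 nM with 12000 nM to 70000 nM as the expected range.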

Compound 4, half-maximal cytotoxic concentration: 15600 nM
Compound 4: middle estimate off by 1.9-fold (0.28 log units), on the high side, within the range that was stated.
By their numbers in this assay, from the lowest: compounds 4 and 2 (each within the scatter of the next); then compound 1.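

The change of chloro to hydrogen cannot be read in this assay while compound 3 has no number, but compound 4 gives two other comparisons. Thiophen-2-yl in place of furan-2-yl gives a 1.2-fold lower number from compound 2 to compound 4 (0.08 log units; within the scatter) and so stays within the scatter, while 1H-1,2,4-triazol-1-yl in place of 1H-imidazol-1-yl gives a 2.9-fold lower number from compound 1 to compound 4 (0.47 log units; beyond the scatter) and so is a modest step beyond it. Nothing at hand accounts for either step.

From the compounds shown here alone, what the second chloro contributes to the number remains open. So does what a fluoro, a methoxy group or an amine at that place would give.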